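Trifluoromethyl in Place of Nitro in Compound 1

This account rests on a few compounds, and the source may have more. Where it says the series, first, only, none or still open, it means among the compounds named here.

In an ADME assay on MDCK cells (Canis lupus familiaris) for cytotoxicity, read by sulforhodamine B assay, with a stated time of 48 h (a lower number here means a stronger inhibitor, a higher number a weaker inhibitor), compound 1 `O=c1cc(-c2ccccc2)oc2cc(OCCCCNc3nc4ccc([N+](=O)[O-])cc4s3)cc(O)c12` gives 310 ug/mL as its reading. Compound 2 `O=c1cc(-c2ccccc2)oc2cc(OCCCCNc3nc4c(F)cc(F)cc4s3)cc(O)c12` gives 307 ug/mL as its reading, level with compound 1 within the usual scatter of repeated measurements. Compound 3 `O=c1cc(-c2ccccc2)oc2cc(OCCCCNc3nc4ccc(C(F)(F)F)cc4s3)cc(O)c12` has not been measured yet. It differs from compound 1 in one place, with trifluoromethyl in place of nitro on an aromatic carbon. One measured step also takes away the nitro, with 4,6-difluoro-1,3-benzothiazol-2-yl in place of 6-nitro-1,3-benzothiazol-2-yl on an amine nitrogen (a 1.0-fold lower number from compound 1 to compound 2 (0.00 log units; within the scatter)), and that step lies within the scatter. Among the compounds with values here, no measured compound carries trifluoromethyl, so this single step is thin evidence. In this assay no step beyond the scatter is therefore expected, in either direction, and the estimated step is small (a 1.0-fold lower number from compound 1 to compound 3 (0.01 log units; within the scatter)). In this assay compound 3 is expected at 305 ug/mL with an estimated range from 170 ug/mL to 550 ug/mL around that middle.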

Compound 3, half-maximal inhibitory concentration: 278 ug/mL
Estimate against measurement, compound 3: 1.1-fold (0.04 log units) above; the measured number falls inside the stated range.
By their numbers in this assay, from the lowest: compounds 3, 2 and 1 (each within the scatter of the next).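

Compound 1 and compound 3 differ only in the group on this aromatic carbon, which is para to a fused ring, so this pair isolates the nitro group in a way the earlier step, which also changed the rest of the benzothiazole substitution, could not. In this assay, the change is a 1.1-fold lower number from compound 1 to compound 3 (0.05 log units; within the scatter): replacing nitro, which has two hydrogen-bond acceptors, with trifluoromethyl, which has none, leaves the reading level within the scatter, so in this pair the nitro group is not required for that reading. Nothing measured on these compounds explains this outcome, so the result stands as an observation without a stated cause.

Nitro and trifluoromethyl both carry no net charge and no hydrogen-bond donors, so it remains open whether the reading would hold with an amine or a carboxylic acid on this aromatic carbon. Also open, going by these compounds, is whether it would stay level with a longer chain linking the core to the amine nitrogen.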